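Changing the outer ring of compound 2

The source may hold more compounds than are shown below. What is called first, only, known or untested is meant among the compounds shown, and "the series" means these compounds.

Compound 2 `Cc1ccccc1-c1cc(Cl)cc(Cl)c1/C=C/[C@@H]1C[C@@H](O)CC(=O)O1` has the highest number of the two measured here: in an assay for inhibition of 3-hydroxy-3-methylglutaryl-coenzyme A reductase (Rattus norvegicus) (a higher number here means a weaker inhibitor, a lower number a stronger inhibitor), compound 2 gives 370 nM, while compound 1 `Cc1cc(-c2cc(Cl)cc(C)c2/C=C/[C@@H]2C[C@@H](O)CC(=O)O2)ccc1F` gives 6 nM. Compound 3 `O=C1C[C@H](O)C[C@@H](/C=C/c2c(Cl)cc(Cl)cc2-c2ccc(Cl)c(Cl)c2)O1` has not been measured. It differs from compound 2 in one place (3,4-dichlorophenyl in place of 2-methylphenyl on an aromatic carbon). Among the compounds with values here, no step between measured compounds is known, so the expectation rests on the values of compound 1 and compound 2 alone. In this assay compound 3 is expected to show a moderate improvement, a step from compound 2 to compound 3 of a 6.2-fold lower number from compound 2 to compound 3 (0.79 log units; beyond the scatter). The estimated value for compound 3 is 60 nM, within a range from 10 nM to 350 nM.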

Compound 3, half-maximal inhibitory concentration: 25 nM
Estimate against measurement, compound 3: 2.4-fold (0.38 log units) above; low and high end bracket the measured number.
By their numbers in this assay, from the lowest: compound 1; then compound 3; then compound 2.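

In this assay, putting 3,4-dichlorophenyl in place of 2-methylphenyl gives a 15-fold lower number from compound 2 to compound 3 (1.17 log units; beyond the scatter) and this large step shows that the outcome at this position depends strongly on what the outer ring carries. Both rings are six-membered carbon aromatic rings without hydrogen-bond donors or acceptors, so those counts do not separate compound 2 from compound 3. Nothing available explains the size of this step. The swap removes a methyl and adds two chlorines at once, so the contribution of each remains unresolved. From the compounds shown here alone, how a methoxy group or an amine on the outer ring would fare also remains open.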